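The compounds below may be only part of what the source reports. "The series", "measured", "known", "first", "only" and "open" are said of these compounds alone.

Measured in a functional assay on T47D cells (Homo sapiens) for inhibition; on this read-out lower numbers stand for stronger inhibition and higher numbers for weaker inhibition:

Compound 1, `Oc1cccc(-c2cc(-c3cccc(F)c3)cc(-c3cccc(O)c3)n2)c1`: 21300 nM
Compound 2, `Oc1cccc(-c2cc(-c3cccc(C(F)(F)F)c3)cc(-c3cccc(O)c3)n2)c1`: 4970 nM
Compound 3, `Oc1cccc(-c2cc(-c3ccc(C(F)(F)F)cc3)cc(-c3cccc(O)c3)n2)c1`: 2330 nM

Compound 3 gives the lowest number of the three in this assay. Its nearest neighbour is compound 2, a step of a 2.1-fold lower number from compound 2 to compound 3 (0.33 log units; beyond the scatter), and the furthest is compound 1, a step of a 9.1-fold lower number from compound 1 to compound 3 (0.96 log units; beyond the scatter). Both steps lie beyond the scatter, so compound 3 is the strongest inhibitor among the measured compounds.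

Compound 4, `Oc1cccc(-c2cc(-c3ccc(OC(F)(F)F)cc3)cc(-c3cccc(O)c3)n2)c1`, is the next step. The change from compound 3 is trifluoromethoxy in place of trifluoromethyl on an aromatic carbon. Within the data shown here, no measured pair swaps these two groups, so nothing bears on it directly. What is known is that changing the group on this ring has moved the number only modestly each time: a 4.3-fold lower number from compound 1 to compound 2 (0.63 log units; beyond the scatter) and a 2.1-fold lower number from compound 2 to compound 3 (0.33 log units; beyond the scatter). The change to trifluoromethoxy is smaller in kind than either of those, so for compound 4 the expected step in this assay is one that stays within the scatter, or at most a small one in either direction: a 1.1-fold lower number from compound 3 to compound 4 (0.02 log units; within the scatter). Compound 4 is therefore estimated at 2200 nM, with a range from 800 nM to 6000 nM.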

Compound 4, half-maximal inhibitory concentration: 9820 nM
Estimate against measurement, compound 4: 4.5-fold (0.65 log units) below, and the stated range ends below it.
By their numbers in this assay, from the lowest: compound 3; then compounds 2 and 4 (each within the scatter of the next); then compound 1.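

In this assay, the exchange of trifluoromethyl for trifluoromethoxy at this place, para to a large group, has a real effect, with a 4.2-fold higher number from compound 3 to compound 4 (0.62 log units; beyond the scatter) and therefore weaker inhibition. The two groups differ by a single inserted oxygen, which adds one heavy atom and one hydrogen-bond acceptor by count, so this position distinguishes between two closely related fluorinated groups, and compound 3 keeps the lowest number of the series. No measurement available here explains why the oxygen-containing group gives the weaker result.

The compounds shown leave open whether the change depends on the oxygen or on the fluorines that come with it, a question that a methyl and a methoxy group at the same place could help to answer. They also leave open how far this position accepts very different groups, such as an amine or a carboxylic acid, and whether the exchange of trifluoromethyl for trifluoromethoxy would give a similar step elsewhere on this ring.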